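A few compounds are considered here, and "the series" means these few. Any claim that something is new, unique, unknown or untested is made for them only; others in the source may bear on it.

Measured compounds in a functional assay on mitochondria from heart for inhibition of peroxisomal acyl-coenzyme A oxidase 1 (Rattus norvegicus); a lower number here means a stronger inhibitor, a higher number a weaker inhibitor:
compound 1 `Cc1nc2cc(OC[C@H](O)CN3CCN(Cc4nc(-c5ccc(C(C)C)cc5)no4)CC3)ccc2s1` gives 1230 nM
compound 2 `Cc1nc2cc(OC[C@H](O)CN3CCN(Cc4nc(-c5ccc(C(F)(F)F)cc5)no4)CC3)ccc2s1` gives 3630 nM
compound 3 `Cc1nc2cc(OC[C@H](O)CN3CCN(Cc4nnc(-c5ccc(C(C)(C)C)cc5)o4)CC3)ccc2s1` gives 1100 nM

Compound 3 has the lowest number of the three. Its nearest neighbour is compound 1, and the gap between them lies within the scatter, so no order between compound 3 and compound 1 can be read from these numbers. Compound 2 lies beyond the scatter above both of them.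

Compound 4 `Cc1nc2cc(OC[C@H](O)CN3CCN(Cc4nnc(-c5ccc(Cl)cc5)o4)CC3)ccc2s1` is not yet measured. It differs from compound 3 by chloro in place of tert-butyl on an aromatic carbon.

For the measured compounds named here, no measured pair makes exactly this change. The step that comes nearest is a 3.0-fold higher number from compound 1 to compound 2 (0.47 log units; beyond the scatter), where isopropyl gave way to trifluoromethyl on an aromatic carbon and the number rose modestly. That step starts from compound 1, whose value sits within the scatter of compound 3. Taking it as the only guide, a modest rise in this assay is expected for compound 4 as well, so that compound 4 is expected to be weaker than compound 3 by a 2.0-fold higher number from compound 3 to compound 4 (0.30 log units; within the scatter). The pair of groups exchanged is not the same as in the measured step, so the expectation is held loosely.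

Compound 4 is estimated at 2200 nM, with a range from 900 nM to 5500 nM.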

Compound 4, half-maximal inhibitory concentration: 8500 nM
Compound 4: the middle estimate sits 3.9-fold (0.59 log units) below what was measured; the measured number lies above the stated range.
By their numbers in this assay, from the lowest: compounds 3 and 1 (each within the scatter of the next); then compound 2; then compound 4.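

Chloro in place of tert-butyl, para to a large group on the aromatic ring, gives a 7.7-fold higher number from compound 3 to compound 4 (0.89 log units; beyond the scatter) in this assay, so on the core of compound 3 this position does not accept the change without a loss of inhibition beyond the scatter. The position now responds in two separate pairs: alongside this step stands a 3.0-fold higher number from compound 1 to compound 2 (0.47 log units; beyond the scatter), with trifluoromethyl in place of isopropyl, and in both pairs a branched carbon group leaves and the number rises, with neither pair going against this. Nothing measured here explains why the number rises at this position.

As far as these compounds go, whether the rise tracks the loss of the tert-butyl or the arrival of the chloro remains open, as does whether the two pairs would match on a single core. A methoxy or a dimethylamino group in this position on the core of compound 3, or chloro on the core of compound 1, would bear on both questions.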